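This account rests on a few compounds, and the source may have more. Where it says the series, first, only, none or still open, it means among the compounds named here.

Compound 1 `O=C1CC(c2ccccc2OCc2ccc(F)cc2)Oc2ccccc21` gives 42.1% in a functional assay on J774.A1 cells (Mus musculus) for inhibition, read by immunoassay, with a stated time of 12 h, tested at 30 uM; on this read-out higher numbers stand for more inhibition at the one concentration tested (going by the name of the read-out) and lower numbers for less inhibition. Compound 2 `CCCCCOc1ccccc1C1CC(=O)c2ccccc2O1` gives 40.1% in this assay.

Compound 2 stands lowest of the two numbers, with compound 1 nearest; the step of a number 2 percentage points lower from compound 1 to compound 2 (within the scatter) is within the scatter. Compound 3 `CC(C)=CCOc1ccccc1C1CC(=O)c2ccccc2O1` differs from compound 2 by 2-methylprop-1-en-1-yl in place of butyl on a saturated chain carbon bound to an oxygen on an aromatic ring. For the measured compounds named here, the one measured step, which altered the same chain carbon, changed nothing beyond the scatter, so no sizable shift in this assay is expected here either. For compound 3 the estimate is 41%, within 26% to 56%, meaning an expected step of a number 0.9 percentage points higher from compound 2 to compound 3 (within the scatter).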

Compound 3, a percentage reported as inhibition, at one concentration (the size of the read-out at that concentration, not a potency): 40.3%
Beside the measured number, compound 3's estimate is 0.7 percentage points above it, within the range that was stated.
By their numbers in this assay, from the lowest: compounds 2, 3 and 1 (each within the scatter of the next).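

Putting 2-methylprop-1-en-1-yl in place of butyl, which adds a double bond outside aromatic rings, gives a number 0.2 percentage points higher from compound 2 to compound 3 (within the scatter) in this assay and putting it in place of 4-fluorophenyl gives a number 1.8 percentage points lower from compound 1 to compound 3 (within the scatter) at the same place. At this saturated chain carbon bound to an oxygen on an aromatic ring, the saturated chain, the chain with a double bond and the fluorinated aromatic ring therefore cannot be told apart. No available measurement explains this closeness. Still open, as far as these compounds go, is whether an amine, a carboxylic acid or a longer chain at this place would move the number beyond the scatter.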